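Replacing cyano with chloro in compound 1

This account rests on a few compounds, and the source may have more. Where it says the series, first, only, none or still open, it means among the compounds named here.

Measured in a functional assay on the whole organism (stomach) for inhibition, with Rattus norvegicus as the target; a lower number here means that less compound is needed, a higher number that more compound is needed for the effect:
- compound 1 `CC1(C)OC(/C=C/c2ccc(C#N)cc2)=CC1=O` gives 50 mg/kg
- compound 2 `CC1(C)OC(/C=C/c2ccncc2)=CC1=O` gives 20 mg/kg

Of these two numbers, compound 1 holds the higher one, and compound 2 lies below it by more than the usual scatter. Compound 3 `CC1(C)OC(/C=C/c2ccc(Cl)cc2)=CC1=O` has not yet been measured. It keeps the core of compound 1 and differs in one place, with chloro in place of cyano on an aromatic carbon, para to a large group (chloro in place of cyano on an aromatic carbon). Among the compounds with values here, no measured pair differs in one place, so the data offer no direct guide to this exchange. The step expected in this assay (a 1.7-fold lower number from compound 1 to compound 3 (0.22 log units; within the scatter)) is small, toward a lower number and not beyond the scatter. Compound 3 is estimated at 30 mg/kg (expected range 10 mg/kg to 90 mg/kg).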

Compound 3, dose for half-maximal effect: 40 mg/kg
For compound 3 the middle estimate is 1.3-fold (0.12 log units) below the measured one; the measured number falls inside the stated range.
By their numbers in this assay, from the lowest: compounds 2, 3 and 1 (each within the scatter of the next, the first and the last beyond it).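

In this assay, within the data shown here, the exchange of cyano for chloro on an aromatic carbon, para to a large group, gives a first direct reading at this position (a 1.3-fold lower number from compound 1 to compound 3 (0.10 log units; within the scatter)). The step stays within the scatter, so in this single pair the position tolerates the loss of the nitrile, with one heavy atom entering for two and the hydrogen-bond acceptor gone, without a change that can be told from repeat variation. Nothing available accounts for this similarity between the two groups. Still open, as far as these compounds go, is how a methoxy group, an amine or a carboxylic acid would read at the same position. From the compounds shown here alone, it is also open whether the exchange of cyano for chloro would read the same way on a different core.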